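The source may hold more compounds than are shown below. What is called first, only, known or untested is meant among the compounds shown, and "the series" means these compounds.

Working notes on the series in an assay on HEK293 cells for displacement of a labelled ligand from C-X-C chemokine receptor type 3 (Homo sapiens); on this read-out higher numbers stand for weaker inhibition and lower numbers for stronger inhibition. Compound 1 `CN(CC1=CC[C@H]2C[C@@H]1C2(C)C)Cc1ccc(Cl)cc1` gives 2510 nM in this assay. Compound 2 `CN(CC1=CC[C@H]2C[C@@H]1C2(C)C)Cc1ccc(-c2cccc(C(F)(F)F)c2)cc1` returns only a limit in this assay, > 316 nM, not a number. Compound 3 `CC(=O)c1cccc(-c2ccc(CN(C)CC3=CC[C@H]4C[C@@H]3C4(C)C)cc2)c1` likewise returns only a limit in this assay, > 316 nM, not a number. Compound 3 therefore has no numerical value of its own; of the three values shown, two sit at the limit of > 316 nM in this assay, at which 2 of the 3 values shown sit, and only compound 1 carries a number. The step that the limit leaves unreadable from compound 1 to compound 3 cannot be sized, and the same holds for a step that the two limits leave unreadable from compound 2 to compound 3; both are unreadable.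

Compound 4 `CN(CC1=CC[C@H]2C[C@@H]1C2(C)C)Cc1ccc(-c2cccc([N+](=O)[O-])c2)cc1` is the next member, not yet measured. Its change from compound 3 is nitro in place of acetyl on an aromatic carbon. The measured steps that bear on this change are the two that end at compound 3, and neither yields a size or a direction. With compound 3 itself known only as a limit, no step beyond the scatter can be predicted in this assay in either direction, and the step that the limit leaves unreadable from compound 3 to compound 4 is expected to be unreadable in the same way. Compound 4 is therefore estimated at 1500 nM in this assay, with a range of 350 nM to 8000 nM, and a further limit rather than a number is the likelier outcome.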

Compound 4, inhibition constant: 2000 nM
Compound 4: the middle estimate sits 1.3-fold (0.12 log units) below what was measured, and the stated range covers the measured number.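

Among the compounds with a substituted phenyl in place of chloro, compound 4 alone returns a number in this assay, so this position now has a readable comparison with the chloro compound. The exchange of chloro for 3-nitrophenyl is a 1.3-fold lower number from compound 1 to compound 4 (0.10 log units; within the scatter), which shows that this large group, with nitro on its ring, can take the place of chloro with no change beyond the scatter on this read-out. The steps from compound 2 and from compound 3 to compound 4 cannot be read, so the exchange of nitro for acetyl or for trifluoromethyl has no size or direction: the limit of > 316 nM in this assay, at which 2 of the 4 values shown sit.

Still open, on these data alone, is whether 3-acetylphenyl and the trifluoromethyl-bearing phenyl group differ at all from 3-nitrophenyl, since only a number for each of them in this assay could settle it. Also open, as far as these compounds go, is whether any group at this place moves the value beyond the scatter relative to compound 1, for instance an amine or a carboxylic acid in place of nitro on the same ring.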